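A few compounds are considered here, and "the series" means these few. Any claim that something is new, unique, unknown or untested is made for them only; others in the source may bear on it.

Compound 1 `O=C(O)CN1C(=O)/C(=C/c2nc3ccccc3n2Cc2ccc([N+](=O)[O-])cc2)SC1=S` gives 7760 nM in a functional assay on MDA-MB-231 cells (Homo sapiens) for cytotoxicity, read by MTT assay, with a stated time of 48 h; on this read-out higher numbers stand for weaker inhibition and lower numbers for stronger inhibition.
Compound 2 `O=C(O)CN1C(=O)/C(=C/c2nc3ccccc3n2Cc2ccc(F)cc2)SC1=S` gives 2620 nM in this assay.
Compound 3 `O=C(O)CN1C(=O)/C(=C/c2nc3ccccc3n2Cc2ccc(F)c(F)c2)SC1=S` gives 3760 nM in this assay.

Compound 2 stands at the low end of these three numbers: it is separated from compound 1 by a 3.0-fold lower number from compound 1 to compound 2 (0.47 log units; beyond the scatter), beyond the scatter, whereas compound 3 lies within the scatter of it. Compound 4 `CCn1c(/C=C2\SC(=S)N(CC(=O)O)C2=O)nc2ccccc21` differs from compound 2 by methyl in place of 4-fluorophenyl on a saturated chain carbon bound to an aromatic nitrogen. Among the measured compounds shown here, no measured step removes the ring itself; a 3.0-fold lower number from compound 1 to compound 2 (0.47 log units; beyond the scatter) and a 1.4-fold higher number from compound 2 to compound 3 (0.16 log units; within the scatter) only exchange the group carried on that ring, and both are modest or within the scatter. Taking away the whole ring is a larger change than any of these, so a higher number, meaning weaker inhibition, is expected for compound 4, with wide uncertainty: a 2.5-fold higher number from compound 2 to compound 4 (0.39 log units; beyond the scatter). Compound 4 is therefore estimated at 6500 nM, within 2200 nM to 20000 nM.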

Compound 4, half-maximal inhibitory concentration: 1880 nM
Beside the measured number, compound 4's estimate is 3.5-fold (0.54 log units) above it; measured number below the stated range.
By their numbers in this assay, from the lowest: compounds 4, 2 and 3 (each within the scatter of the next); then compound 1.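

Swapping the whole aromatic ring for a methyl on this saturated chain carbon bound to an aromatic nitrogen does not weaken inhibition in this assay for two of the three pairs: a 1.4-fold lower number from compound 2 to compound 4 (0.14 log units; within the scatter) and a 2.0-fold lower number from compound 3 to compound 4 (0.30 log units; within the scatter) are both small steps. Against the 4-nitrophenyl group, the same swap gives a 4.1-fold lower number from compound 1 to compound 4 (0.62 log units; beyond the scatter) as the one clear step, so among these compounds the ring is not required for activity here. Nothing available explains this result. On these data alone, what a longer chain such as butyl, or a chain ending in an amine, would do at this position stays open.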